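This account rests on a few compounds, and the source may have more. Where it says the series, first, only, none or still open, it means among the compounds named here.

In an in vitro functional assay on HEK285-7 cells for antagonist activity at prostaglandin D2 receptor 2 (Homo sapiens), read by BRET and beta-arrestin recruitment (on this read-out lower numbers stand for stronger inhibition and higher numbers for weaker inhibition), the measured compounds stand as follows:

- Compound 1 `O=C(O)Cc1sc(C(c2ccc(F)cc2)c2ccc(F)cc2)nc1-c1ccnc(N2CCCC2)c1`: > 100000 nM
- Compound 2 `COc1cc(-c2nc(C(c3ccc(F)cc3)c3ccc(F)cc3)sc2CC(=O)O)ccn1`: 380 nM
- Compound 3 `O=C(O)Cc1sc(C(c2ccc(F)cc2)c2ccc(F)cc2)nc1-c1cccc(F)c1`: 18 nM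

The value of compound 1 is a limit of the assay, not a number (the limit of > 100000 nM in this assay, at which 1 of the 3 values shown sits). Compound 3 has the lowest of the two actual numbers, with compound 2 the nearest at a 21-fold lower number from compound 2 to compound 3 (1.32 log units; beyond the scatter). The change to compound 4 `N#Cc1ccc(-c2nc(C(c3ccc(F)cc3)c3ccc(F)cc3)sc2CC(=O)O)cc1` is 4-cyanophenyl in place of 3-fluorophenyl on an aromatic carbon. Going by the values given here, no measured step swaps one substituent on a phenyl for another; the steps of an at least 5500-fold lower number from compound 1 to compound 3 (3.74 log units; beyond the scatter) and a 21-fold lower number from compound 2 to compound 3 (1.32 log units; beyond the scatter) only show that this group matters greatly in this assay. A modest weakening is therefore expected, a 3.3-fold higher number from compound 3 to compound 4 (0.52 log units; beyond the scatter). Compound 4 is estimated at 60 nM, in the range 10 nM to 400 nM.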

Compound 4, half-maximal inhibitory concentration: 1500 nM
For compound 4 the middle estimate is 25-fold (1.40 log units) below the measured one; the measured number lies above the stated range.
By their numbers in this assay, from the lowest: compound 3; then compound 2; then compound 4. At a limit, above all of these: compound 1.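

In this assay, this position separates two plain substituted phenyl groups sharply: an 83-fold higher number from compound 3 to compound 4 (1.92 log units; beyond the scatter), so 4-cyanophenyl is no close stand-in for 3-fluorophenyl. The same change places 4-cyanophenyl behind 2-methoxypyridin-4-yl, with a 3.9-fold higher number from compound 2 to compound 4 (0.60 log units; beyond the scatter), and ahead of 2-(pyrrolidin-1-yl)pyridin-4-yl, with an at least 66-fold lower number from compound 1 to compound 4 (1.82 log units; beyond the scatter). Compound 1 stands at a limit, not a number: the limit of > 100000 nM in this assay, at which 1 of the 4 values shown sits.

The compounds shown leave open whether the loss follows the nitrile itself or its place on the phenyl ring. A 3-cyanophenyl or a 4-fluorophenyl group on the same core would separate the two.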